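The source may hold more compounds than are shown below. What is called first, only, known or untested is meant among the compounds shown, and "the series" means these compounds.

Compound 1 `Cc1ccc(C2=NN(c3nc(-c4ccccc4)cs3)C(c3ccc(F)cc3)C2)s1` was tested in a functional assay on A549 cells (Homo sapiens) for antiproliferative activity, read by XTT assay, with a stated time of 24 h; on this read-out lower numbers stand for stronger inhibition and higher numbers for weaker inhibition. In this assay compound 1 gives > 500 ug/mL, which is a limit of the assay and not a number. Compound 2 `Fc1ccc(C2CC(c3ccc(Cl)s3)=NN2c2nc(-c3ccccc3)cs2)cc1` differs from compound 1 by a chloro in place of a methyl on an aromatic carbon. In this assay compound 2 gives > 500 ug/mL, again a limit rather than a number. The step that the two limits leave unreadable from compound 1 to compound 2 therefore has no readable size, as the limit of > 500 ug/mL in this assay, at which 2 of the 2 values shown sit, records. Compound 3 `Cc1ccc(C2=NN(c3nc(-c4ccc(C#N)cc4)cs3)C(c3ccc(F)cc3)C2)s1`, not yet measured, differs from compound 1 by cyano in place of hydrogen on an aromatic carbon; cut one bond further out, the change reads as phenyl to 4-cyanophenyl. Within the data shown here, no measured step touches a change of this kind, and the one measured step gives no size at all. With nothing in the shown numbers pointing toward stronger inhibition, the step of a number no higher from compound 1 to compound 3 (the limit leaves the size open) is expected to be small. Compound 3 is therefore estimated to sit at 500 ug/mL in this assay, within a range from 200 ug/mL to 1200 ug/mL, most likely again reported only as a limit.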

Compound 3, half-maximal inhibitory concentration: 322 ug/mL
Compound 3: the middle estimate sits 1.6-fold (0.19 log units) above what was measured; the measured number falls inside the stated range.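

Among these compounds, the change from phenyl to 4-cyanophenyl is the first in this set to give a measured number rather than a limit, which makes this place, on a six-membered aromatic ring of carbon only and para to a large group, the first where a change can be sized at all in this assay. The step is an at least 1.5-fold lower number from compound 1 to compound 3 (0.19 log units; that floor lies within the scatter); that floor alone does not set the pair apart from ordinary variation between repeats, though the true gap could be wider. Compound 1 is recorded only as a limit, as is compound 2, which leaves the chloro-for-methyl step unreadable, and the limit still dominates the set: the limit of > 500 ug/mL in this assay, at which 2 of the 3 values shown sit.

The compounds shown leave open whether the cyano group itself matters or whether another group at this place, such as an amine, a carboxylic acid or a methoxy group, would give a similar number. They also leave open how far compound 1 truly lies from compound 3, and whether a cyano group elsewhere on the same ring would give a readable value.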